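The compounds below may be only part of what the source reports. "The series", "measured", "known", "first", "only" and "open" are said of these compounds alone.

Compound 1 `COc1cc(C(c2ccc(O)c(OC)c2)[C@@H](C)[C@@H](C)CO)ccc1O` reads > 100000 nM in a functional assay on HeLa cells (Homo sapiens) for cytotoxicity, read by WST assay, with a stated time of 48 h (on this read-out lower numbers stand for stronger inhibition and higher numbers for weaker inhibition), which is a limit of the assay. Compound 2 `COc1cc(C(c2ccc(O)c(OC)c2)[C@@H](C)C(C)C)ccc1O` gives 19000 nM and compound 3 `COc1cc(C(c2ccc(O)c(OC)c2)[C@H](CF)C(C)C)ccc1O` gives 19000 nM, so compound 3 sits level with compound 2: no change at the digits printed from compound 2 to compound 3 (within the scatter). The next structure is compound 4 `COc1cc(C(c2ccc(O)c(OC)c2)[C@H](C)[C@@H](C)CO)ccc1O`, reached through (2-(hydroxymethyl)-1-methylpropyl in place of 1-(fluoromethyl)-2-methylpropyl on a saturated chain carbon bound to two aromatic carbons), with 2-(hydroxymethyl)-1-methylpropyl in place of 1-(fluoromethyl)-2-methylpropyl on a saturated chain carbon bound to two aromatic carbons. The closest evidence is an at least 5.2-fold lower number from compound 1 to compound 3 (0.72 log units; beyond the scatter), supported by an at least 5.2-fold lower number from compound 1 to compound 2 (0.72 log units; beyond the scatter). Both run opposite to the new step, and each is bounded by a limit. A move to weaker inhibition in this assay is therefore expected, estimated as a 3.7-fold higher number from compound 3 to compound 4 (0.57 log units; beyond the scatter). For compound 4 the estimated value is 70000 nM, with an expected range of 25000 nM to 150000 nM.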

Compound 4, half-maximal inhibitory concentration: > 100000 nM
Compound 4 gave a limit, no number (the forecaster's own chance of this, stated with the estimate: 50%); middle value at least 1.4-fold (0.15 log units) from the limit.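

In this assay, the 2-(hydroxymethyl)-1-methylpropyl chain on the saturated chain carbon bound to two aromatic carbons again goes with weaker inhibition, now in a second drawn configuration: an at least 5.2-fold higher number from compound 3 to compound 4 (0.72 log units; beyond the scatter), and an at least 5.2-fold higher number from compound 2 to compound 4 (0.72 log units; beyond the scatter). The step from compound 1 to compound 4 cannot be read, because both sit at the same limit: the limit of > 100000 nM in this assay, at which 2 of the 4 values shown sit. Neither drawn configuration brings this chain into the measurable range: the fact that compounds 1 and 4 differ only in the configuration as drawn

As far as these compounds go, how far past the limit compound 1 and compound 4 lie remains open. Also open, from the compounds shown here alone, is whether an amine or a carboxylic acid in place of the hydroxy would read like compound 4 or like compound 3.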